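Swapping an Aromatic Ring for a Cyclic Amidine

The compounds below may be only part of what the source reports. "The series", "measured", "known", "first", "only" and "open" are said of these compounds alone.

Compound 2 `CC(C)c1noc(N2CCC(Oc3ncnc4c3CCN4c3ccc(S(C)(=O)=O)cc3F)CC2)n1` gives 124% in a functional assay on CHO-K1 cells with Glucose-dependent insulinotropic receptor (Homo sapiens) as the target, read by a luciferase reporter, with a stated time of 5 h (on this read-out higher numbers stand for larger maximal responses and lower numbers for smaller maximal responses), the higher of two numbers; compound 1 `COCCOC(=O)N1CCC(Oc2ncnc3c2CCN3c2ccc(S(C)(=O)=O)cc2F)CC1` gives 86%. Compound 3 `CS(=O)(=O)c1ccc(N2CCc3c(OC4CCN(C5=NCCCN5)CC4)ncnc32)c(F)c1` carries a group of 6 heavy atoms (4 carbon, 2 nitrogen; one six-membered non-aromatic ring with 2 hetero atoms) in place of a group of 8 heavy atoms (5 carbon, 2 nitrogen, 1 oxygen; one five-membered aromatic ring with 3 hetero atoms), on an amine nitrogen in a ring. Within the data shown here, the only measured step on this nitrogen, a number 38 percentage points higher from compound 1 to compound 2 (beyond the scatter), shows that exchanging the group there can shift the maximal response strongly, but the entering group resembles neither earlier one, so the direction is uncertain. A modest drop, a number 24 percentage points lower from compound 2 to compound 3 (beyond the scatter), is expected. Compound 3 is estimated at 100%, within 60% to 135%.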

Compound 3, largest response reached (reported as percent of maximum), in percent of the reference or control that the assay uses: 66%
Estimate against measurement, compound 3: 34 percentage points above; measured number inside the range.
By their numbers in this assay, from the lowest: compound 3; then compound 1; then compound 2.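

In this assay the cyclic amidine on the amine nitrogen in a ring gives the lowest response of the three compounds, with the fall from the oxadiazole being large (a number 58 percentage points lower from compound 2 to compound 3 (beyond the scatter)) and the fall from the carbamate modest (a number 20 percentage points lower from compound 1 to compound 3 (beyond the scatter)). This nitrogen can therefore lower the maximal response as well as raise it, and the non-aromatic ring falls below both earlier groups. Nothing available explains the fall. The compounds shown leave open whether the ring itself matters or only the atoms that touch this nitrogen. An open-chain guanidine in the same place would help to separate the two.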